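The compounds below may be only part of what the source reports. "The series", "measured", "known", "first", "only" and "open" are said of these compounds alone.

Compound 1 `CCOc1ccc(Br)cc1-c1cc(Nc2cccc(C#N)c2)nc(N)n1` and compound 3 `CCOc1ccc(Cl)cc1-c1cc(Nc2cccc([N+](=O)[O-])c2)nc(N)n1` share one core and differ in the halogen on the outer ring and in the group on the aryl amine; in an assay on Sf9 cells for inhibition of 1-acyl-sn-glycerol-3-phosphate acyltransferase beta (Homo sapiens) (on this read-out lower numbers stand for stronger inhibition and higher numbers for weaker inhibition), compound 1 gives 720 nM, and compound 3 gives 640 nM. Compound 2 `CCOc1ccc(Br)cc1-c1cc(Nc2ccc(C(=N)N)cc2)nc(N)n1` carries an amidine on the aryl amine. In this assay compound 2 gives only a limit, > 5000 nM, and so stands where no exact number is known. Among the compounds with values here, the one measured step that bears on the new compound runs an at least 6.9-fold higher number from compound 1 to compound 2 (0.84 log units; beyond the scatter), because the amidine brought the value to the limit of > 5000 nM in this assay, at which 1 of the 3 values shown sits. Compound 4 `CCOc1ccc(Br)cc1-c1cc(Nc2ccc(Cl)cc2)nc(N)n1` is the mirror of that move: one chlorine atom in place of a group of 3 heavy atoms (1 carbon, 2 nitrogen; no ring), on an aromatic carbon. Since the amidine was what pushed compound 2 to the limit, removing it is expected to bring the value back toward the range of compound 1 and compound 3, a gain estimated at an at least 8.3-fold lower number from compound 2 to compound 4 (0.92 log units; beyond the scatter). For compound 4 the expected value in this assay is 600 nM, with a range from 200 nM to 2500 nM.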

Compound 4, half-maximal inhibitory concentration: 16 nM
Compound 4: the middle estimate sits 38-fold (1.57 log units) above what was measured; the measured number lies below the stated range.
By their numbers in this assay, from the lowest: compound 4; then compounds 3 and 1 (each within the scatter of the next). At a limit, above all of these: compound 2.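

In this assay, the group on the aryl ring proves able to move the value far more than the first compounds showed: 4-chlorophenyl in place of 3-cyanophenyl gives a 45-fold lower number from compound 1 to compound 4 (1.65 log units; beyond the scatter). Against the amidine, the chloro group, on an aromatic carbon para to a large group, gives an at least 310-fold lower number from compound 2 to compound 4 (2.49 log units; beyond the scatter). Compound 2 stands only at a limit, so that step gives a lower bound and not a size: the limit of > 5000 nM in this assay, at which 1 of the 4 values shown sits.

The step from compound 1 changes the group and its place on the ring together, so the compounds shown do not tell whether the chloro group itself or its place carries the change. Going by these compounds, whether a bromine, a methoxy group or an amine at this same place would hold the value near that of compound 4 also stays open.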